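The compounds below may be only part of what the source reports. "The series", "measured", "known", "first", "only" and "open" are said of these compounds alone.

In an ADME assay on microsomes from liver (Mus musculus) for metabolic stability, read by LC-MS, using NADPH, with stated times of 10 min and 30 min, tested at 1 uM (on this read-out higher numbers stand for fast clearance and lower numbers for slow clearance), compound 1 (`COC(=O)C1=C(C)NC(c2nccs2)=NC1(C)c1ccc(Cl)cc1`) gives 85 mL/min/kg and compound 2 (`COC(=O)C1=C(C)NC(c2nccs2)=NC1(C)c1ccc(S(C)(=O)=O)cc1`) gives 57 mL/min/kg on the same scale. Compound 3 (`COC(=O)C1=C(CN2CCC(O)C2)NC(c2nccs2)=NC1(C)c1ccc(F)cc1`) gives 83 mL/min/kg and so stands within the scatter of both others, with no meaningful order among the three. Compound 4 (`COC(=O)C1=C(COC(C(=O)O)C(F)(F)F)NC(c2nccs2)=NC1(C)c1ccc(F)cc1`) has yet to be measured. The change leading to it is a group of 9 heavy atoms (3 carbon, 3 oxygen, 3 fluorine; no ring) in place of a group of 6 heavy atoms (4 carbon, 1 nitrogen, 1 oxygen; one five-membered non-aromatic ring with 1 hetero atom), on a saturated chain carbon bound to a double-bonded ring carbon and the 3-hydroxypyrrolidin-1-yl group is thereby lost. Within the data shown here, only one measured step bears on this, and only loosely. It is a 1.5-fold lower number from compound 1 to compound 2 (0.17 log units; within the scatter) with methylsulfonyl in place of chloro on an aromatic carbon. That step lies elsewhere in the molecule and stays within the scatter. Among the measured compounds shown here, no measured step touches a saturated chain carbon bound to a double-bonded ring carbon, so the data give no firm direction for the new group. The expected change is therefore none beyond the scatter, with only a slight lean towards slower clearance. The step expected is a 1.4-fold lower number from compound 3 to compound 4 (0.14 log units; within the scatter) and this remains a wide and uncertain estimate. In this assay compound 4 is estimated at 60 mL/min/kg with an expected range from 28 mL/min/kg to 95 mL/min/kg for this measurement.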

Compound 4, clearance: 24 mL/min/kg
Beside the measured number, compound 4's estimate is 2.5-fold (0.40 log units) above it, and the stated range ends above it.
By their numbers in this assay, from the lowest: compound 4; then compounds 2, 3 and 1 (each within the scatter of the next).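

The saturated chain carbon bound to a double-bonded ring carbon proves to be a place where a change in substituent can move the number in this assay: putting the new group of 9 heavy atoms in place of the 3-hydroxypyrrolidin-1-yl group gives a 3.5-fold lower number from compound 3 to compound 4 (0.54 log units; beyond the scatter) and carries the series outside the scatter. Among these compounds, the only earlier step, on an aromatic carbon, is a 1.5-fold lower number from compound 1 to compound 2 (0.17 log units; within the scatter) and stayed within it, whereas the step at this chain carbon does not, even though the leaving and entering groups have the same counts of hydrogen-bond donors and acceptors, so those counts do not separate the two compounds. No measurement shown here offers an explanation for the size or direction of this step.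

Which part of the entering group goes with the lower number stays open, as its carboxylic acid and trifluoromethyl arrive together with the loss of the ring. A primary amide in place of the carboxylic acid, or a plain methyl in place of the trifluoromethyl, would be needed at this carbon to separate them, and the compounds shown do not settle how either would read.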